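Dimethylphenyl for Fluorophenyl on the Sulfone: Expected Clearance

This account rests on a few compounds, and the source may have more. Where it says the series, first, only, none or still open, it means among the compounds named here.

Compound 1 `Cc1ccc(S(=O)(=O)c2cnc3cc(F)ccc3c2-c2ccc(F)cc2)cc1C`: 9.25 mL/min
Compound 2 `O=S(=O)(c1cccc(F)c1)c1cnc2cc(F)ccc2c1-c1ccc(F)cc1`: 0.11 mL/min
Compound 3 `O=S(=O)(c1cccc(F)c1)c1cnc2cc(F)ccc2c1-c1cccc(F)c1`: 0.24 mL/min

In an ADME assay on microsomes from liver (Homo sapiens) for metabolic stability, tested at 2.5 uM (on this read-out lower numbers stand for slow clearance and higher numbers for fast clearance), compound 2 gives 0.11 mL/min. The core of compound 3 differs from that of compound 2 by 3-fluorophenyl in place of 4-fluorophenyl on an aromatic carbon. Compound 3 gives 0.24 mL/min, a step of a 2.2-fold higher number from compound 2 to compound 3 (0.34 log units; beyond the scatter). Compound 1 carries 3,4-dimethylphenyl in place of 3-fluorophenyl on a sulfonyl sulfur and gives 9.25 mL/min, so that change produced an 84-fold higher number from compound 2 to compound 1 (1.92 log units; beyond the scatter).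

Compound 4 `Cc1ccc(S(=O)(=O)c2cnc3cc(F)ccc3c2-c2cccc(F)c2)cc1C` is not yet measured. It differs from compound 3 by 3,4-dimethylphenyl in place of 3-fluorophenyl on a sulfonyl sulfur, the same change as from compound 2 to compound 1, at a place described in the same words; among these compounds it occurs twice. Going by the values given here, because its one measured instance gave an 84-fold higher number from compound 2 to compound 1 (1.92 log units; beyond the scatter), compound 3 to compound 4 is expected to show a 63-fold higher number from compound 3 to compound 4 (1.80 log units; beyond the scatter) in this assay. Compound 4 is therefore estimated at 15 mL/min, expected between 4 mL/min and 45 mL/min.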

Compound 4, intrinsic clearance in a liver preparation (reported as CLH), per the amount of preparation that the assay uses: 3.71 mL/min
Compound 4: middle estimate off by 4.0-fold (0.61 log units), on the high side; the whole stated range lies above it.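

In this assay the change to 3,4-dimethylphenyl in place of 3-fluorophenyl on a sulfonyl sulfur again gave a rise (this time a 15-fold higher number from compound 3 to compound 4 (1.19 log units; beyond the scatter)) so its direction carried to the second core while its size did not: the same change on two cores in this assay, an 84-fold higher number (1.92 log units; beyond the scatter) from compound 2 to compound 1 and a 15-fold higher number (1.19 log units; beyond the scatter) from compound 3 to compound 4, 5.4-fold (0.74 log units) apart, beyond the scatter of two such steps.
The change to 3-fluorophenyl in place of 4-fluorophenyl on an aromatic carbon did not keep even its direction, giving a 2.5-fold lower number from compound 1 to compound 4 (0.40 log units; beyond the scatter) on the core bearing 3,4-dimethylphenyl: the same change on two cores in this assay, a 2.2-fold higher number (0.34 log units; beyond the scatter) from compound 2 to compound 3 and a 2.5-fold lower number (0.40 log units; beyond the scatter) from compound 1 to compound 4, 5.4-fold (0.74 log units) apart, beyond the scatter of two such steps.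
Each change therefore depends on what the other place carries, but four compounds do not show why, or how either change would behave on a further core.

The compounds shown leave open whether a single methyl group on that ring would bring the same rise in this assay as the two methyl groups do. They also leave open how a methoxy group or a pyridine ring would read there.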